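Pyrazolyl in place of amino: expectation for compound 3

The source may hold more compounds than are shown below. What is called first, only, known or untested is meant among the compounds shown, and "the series" means these compounds.

Measured compounds:
Compound 1 `COc1ccc2c(OCCn3c(=O)oc4cc(OC)ccc43)ccnc2c1` — in a functional assay on EBC-1 cells (Homo sapiens) for inhibition, read by sulforhodamine B assay, with a stated time of 72 h (a higher number here means a weaker inhibitor, a lower number a stronger inhibitor), compound 1 gives > 500 nM, which is a limit of the assay.
Compound 2 `COc1ccc2c(OCCn3c(=O)oc4cc(N)ccc43)ccnc2c1` — in this assay compound 2 gives 160 nM.

Going by the values given here, compound 2 stands as the only actual number in this assay; the other value shown is a limit, (the limit of > 500 nM in this assay, at which 1 of the 2 values shown sits). Among the compounds with values here, the single measured step is an at least 3.1-fold lower number from compound 1 to compound 2 (0.49 log units; beyond the scatter), so exchange at this aromatic carbon has already moved the read-out at least modestly, though only its lower bound is known.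

Compound 3 `COc1ccc2c(OCCn3c(=O)oc4cc(-c5cnn(C)c5)ccc43)ccnc2c1` carries a further exchange at the same carbon: 1-methyl-1H-pyrazol-4-yl in place of amino on an aromatic carbon. Within the data shown here, no measured step covers an aryl group entering at this position, so the step from compound 1 to compound 2 bears on it only as a sign that this carbon is tolerant of change. An expected step of a 1.3-fold lower number from compound 2 to compound 3 (0.12 log units; within the scatter) is taken, with wide uncertainty in either direction. Compound 3 is therefore estimated at 120 nM, with a range from 40 nM to 400 nM.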

Compound 3, half-maximal inhibitory concentration: 100 nM
Beside the measured number, compound 3's estimate is 1.2-fold (0.08 log units) above it; low and high end bracket the measured number.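

In this assay, replacing amino with 1-methyl-1H-pyrazol-4-yl gives a 1.6-fold lower number from compound 2 to compound 3 (0.20 log units; within the scatter), so this aromatic carbon accepts a group of 6 heavy atoms carrying a five-membered aromatic ring, and compounds 2 and 3 read alike. The hydrogen-bond donor count of the group falls from 1 to 0 across that step, so a value at this level does not depend on a donor at this carbon in these two compounds. Methoxy is now the group that stands apart, with an at least 5.0-fold lower number from compound 1 to compound 3 (0.69 log units; beyond the scatter) as a second replacement beyond the scatter, but the value of compound 1, > 500 nM, is a limit, and the full size of the step stays unknown because of where that value stands: the limit of > 500 nM in this assay, at which 1 of the 3 values shown sits.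

Open, on these data alone, is what separates methoxy from the two better groups, since a methyl, a hydroxyl, a dimethylamino group or a carboxylic acid at this carbon would test more than these three compounds can. Also open, as far as these compounds go, is whether a phenyl ring or an unmethylated pyrazole would read like compound 3, and whether the same exchanges hold on any other part of the shared core.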